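Working notes: methoxy for hydrogen, compound 2 to compound 3

The compounds below may be only part of what the source reports. "The series", "measured", "known", "first", "only" and "open" are said of these compounds alone.

Measured so far:
compound 1 `COc1ccc(-c2cc(/C=C/C(=O)c3cc(OC)c(OC)c(OC)c3)[nH]n2)cc1OC` – 81%
compound 2 `COc1ccc(C(=O)/C=C/c2cc(-c3cc(OC)c(OC)c(OC)c3)n[nH]2)cc1OC` – 98%

In a functional assay on SF-539 cells (Homo sapiens) for cytotoxicity, read by sulforhodamine B assay, with a stated time of 48 h, tested at 0.1 uM (a higher number here means a weaker effect of the compound at the concentration tested, a lower number a stronger effect), compound 2 gives 98%, the highest of the two numbers obtained to date. The nearest, compound 1, gives 81% in this assay, a gap that lies beyond the usual scatter, so compound 2 shows the weaker effect of the pair at the concentration tested.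

Compound 3 `COc1cc(C(=O)/C=C/c2cc(-c3cc(OC)c(OC)c(OC)c3)n[nH]2)cc(OC)c1OC` differs from compound 2 by methoxy in place of hydrogen on an aromatic carbon. Among the measured compounds shown here, no step between measured compounds with a single change is available, so no measured step can guide the direction. With compound 2 already near the top of the scale, the step of a number 8 percentage points lower from compound 2 to compound 3 (within the scatter) is expected to be small, either none beyond the scatter or a modest move toward a lower number. Compound 3 is therefore estimated at 90%, with a range from 72% to 105%.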

Compound 3, a percentage reported as activity, at one concentration (the size of the read-out at that concentration, not a potency): 91%
Beside the measured number, compound 3's estimate is 1 percentage points below it; measured number inside the range.
By their numbers in this assay, from the lowest: compounds 1, 3 and 2 (each within the scatter of the next, the first and the last beyond it).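

In this assay, methoxy in place of hydrogen on an aromatic carbon now has two measured steps, a number 7 percentage points lower from compound 2 to compound 3 (within the scatter) and a number 10 percentage points higher from compound 1 to compound 3 (within the scatter). Among the compounds shown here, this is the first single-place information, and it shows that methoxy at this position, ortho to a methoxy group and meta to a large group, gives no step beyond the scatter from either neighbour. No measured evidence bears on why these steps are this size.

On these data alone, whether an amine, a hydroxy group or a longer chain such as ethoxy at this position would move the number beyond the scatter stays open. As far as these compounds go, these compounds also give one read-out at one concentration, so their potency across a range of concentrations remains open.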